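The source may hold more compounds than are shown below. What is called first, only, known or untested is meant among the compounds shown, and "the series" means these compounds.

Measured compounds:
- compound 1, `O=C(Cn1c(=O)oc2cc([N+](=O)[O-])ccc21)Nc1ccccn1`: 47.3%
- compound 2, `O=C(Cn1c(=O)oc2ccccc21)NCc1cccs1`: 49.1%
- compound 3, `O=C(Cn1c(=O)oc2ccccc21)Nc1ccccc1`: 39.8%

These three were tested in an ADME assay on RAW264.7 cells (Mus musculus) for cytotoxicity, read by MTT assay, with a stated time of 72 h, tested at 100 uM; on this read-out higher numbers stand for a stronger effect at the one concentration tested and lower numbers for a weaker effect. Compound 3 gives the smallest of the three numbers, yet this sets it apart from neither of the others: compound 1 gives 47.3% and compound 2 gives 49.1%, and both gaps fall within the usual scatter, so the three numbers are best read as one group. Among the compounds with values here, the only single-point step among them, a number 9.3 percentage points lower from compound 2 to compound 3 (within the scatter), is itself within the scatter.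

Compound 4, `O=C(Cn1c(=O)oc2ccccc21)Nc1ccccn1`, is not yet measured. It differs from compound 3 by pyridin-2-yl in place of phenyl on an amide-type nitrogen. Within the data shown here, no measured pair shows this change on its own: compound 1 carries the pyridin-2-yl group, but it also carries a nitro group on the shared core, so its number against compound 3 cannot be read as the effect of one change. What the data show is that swapping the group on the amide-type nitrogen, as in a number 9.3 percentage points lower from compound 2 to compound 3 (within the scatter), stayed within the scatter. By that reading the step of a number 4.2 percentage points higher from compound 3 to compound 4 (within the scatter) is expected to stay within the scatter too, in no settled direction. Compound 4 is therefore estimated at 44%, between 30% and 58%.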

Compound 4, a percentage reported as inhibition, at one concentration (the size of the read-out at that concentration, not a potency): 28.4%
For compound 4 the middle estimate is 15.6 percentage points above the measured one; the whole stated range lies above it.
By their numbers in this assay, from the lowest: compound 4; then compounds 3, 1 and 2 (each within the scatter of the next).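

In this assay, pyridin-2-yl in place of phenyl on the amide-type nitrogen comes with a number 11.4 percentage points lower from compound 3 to compound 4 (beyond the scatter), and pyridin-2-yl in place of (thiophen-2-yl)methyl at the same place comes with a number 20.7 percentage points lower from compound 2 to compound 4 (beyond the scatter), so changes at this position can reach beyond the scatter, which the earlier step there did not show. Within the data shown here, with pyridin-2-yl kept on that nitrogen, hydrogen in place of nitro on an aromatic carbon comes with a number 18.9 percentage points lower from compound 1 to compound 4 (beyond the scatter), which shows for the first time that the nitro group on the shared core also counts in this read-out. No measurement available here explains either change.

The compounds shown leave open whether the lower number belongs to pyridin-2-yl in particular or would also appear with pyridin-3-yl or pyridin-4-yl on the amide-type nitrogen. Going by these compounds, it is also open whether nitro would act in the same way in a compound with phenyl on that nitrogen, and what an amine in place of nitro on the aromatic carbon would give.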